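The source may hold more compounds than are shown below. What is called first, only, known or untested is meant among the compounds shown, and "the series" means these compounds.

The measured compounds:
compound 1, `O=C1CC(c2ccccc2F)n2ncnc2N1`, which in a functional assay on the whole organism (strain Kunming) with Mus musculus as the target (a higher number here means that more compound is needed for the effect, a lower number that less compound is needed), gives 31.7 mg/kg;
compound 2, `O=C1CC(c2ccccc2Cl)n2ncnc2N1`, which in this assay gives 25.5 mg/kg;
compound 3, `O=C1CC(c2ccccc2F)n2nccc2N1`, which in this assay gives 47.3 mg/kg.

Compound 1 and compound 2 share one core, while compound 3 carries another; the difference between the two cores is not broken down here. Between compound 1 and compound 2 the change is chloro in place of fluoro on an aromatic carbon, and in this assay this gave a 1.2-fold lower number from compound 1 to compound 2 (0.09 log units; within the scatter). Compound 3 differs from compound 1 and from compound 2 in both the core and that substituent, and its value lies within the scatter of each of theirs, so no order among the three can be read from these numbers.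

Compound 4, `O=C1CC(c2ccccc2Cl)n2nccc2N1`, has not yet been measured. It differs from compound 3 by chloro in place of fluoro on an aromatic carbon, the same change, at the same place, that separates compound 1 from compound 2. Because a 1.2-fold lower number from compound 1 to compound 2 (0.09 log units; within the scatter) lay within the scatter, a step of similar size is expected here, a 1.2-fold lower number from compound 3 to compound 4 (0.07 log units; within the scatter). Compound 4 is therefore estimated at 40 mg/kg in this assay, with a likely range from 25 mg/kg to 65 mg/kg.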

Compound 4, dose for half-maximal effect: 63.4 mg/kg
The estimate for compound 4 lay 1.6-fold (0.20 log units) below the measured number; the range from low to high includes it.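

On the second core, chloro in place of fluoro on an aromatic carbon, ortho to a large group, gave a 1.3-fold higher number from compound 3 to compound 4 (0.13 log units; within the scatter) in this assay. Set beside the step on the first core, this step shows no difference that can be told from the scatter: the same change on two cores in this assay, a 1.2-fold lower number (0.09 log units; within the scatter) from compound 1 to compound 2 and a 1.3-fold higher number (0.13 log units; within the scatter) from compound 3 to compound 4, 1.7-fold (0.22 log units) apart, within the scatter of two such steps

Within these two pairs, then, the change carries from one core to the other without a detectable difference, and on neither core does it move the number beyond the scatter. This does not show that the two cores respond alike in general, since steps this small could hide a real difference, and two pairs support no rule for the series.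

The compounds shown leave open what a methyl, a methoxy or a trifluoromethyl group would do at this place on the ring, since only fluoro and chloro appear there. They also leave open the effect of replacing the amide hydrogen with a longer chain, or of adding an amine elsewhere on the ring, on either core.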